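A Fluorinated Side Chain on a Weak Cell-Growth Inhibitor

The source may report more compounds than this note shows. Statements on the series, on what has been measured and on what is new or still open speak of the compounds shown alone.

Of the compounds shown here, three with a shared core have been measured so far. Compound 1 `CCOc1ccc(C2CC2C(=O)NNC(=O)c2ccncc2)cc1` was tested in a functional assay on U-373MG ATCC cells (Homo sapiens) for inhibition, read by MTT assay, with a stated time of 72 h (a lower number here means a stronger inhibitor, a higher number a weaker inhibitor), and gives 63000 nM. Compound 2 `O=C(NNc1nncc2ccccc12)C1CC1c1ccc(OC(F)(F)F)cc1` gives 85000 nM in this assay, and compound 3 `CCOc1ccc(C2CC2C(=O)NNc2nncc3ccccc23)cc1` gives 91000 nM. Compound 1 has the lowest of the three numbers, but its gaps to compound 2 and to compound 3 both lie within the scatter, so none of the three can be set apart from the others. For the measured compounds named here, the only step between two compounds that differ in a single place is a 1.1-fold higher number from compound 2 to compound 3 (0.03 log units; within the scatter), a swap within the group on the aromatic oxygen that made no difference beyond the scatter.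

Compound 4 `O=C(NNC(=O)C1CC1c1ccc(OCC(F)(F)F)cc1)c1ccncc1` differs from compound 1 in one place: trifluoromethyl in place of methyl on a saturated chain carbon bound to an oxygen on an aromatic ring. The measured step that bears on this is the fluorine-for-no-fluorine exchange on the aromatic oxygen in the step from compound 2 to compound 3, and because a 1.1-fold higher number from compound 2 to compound 3 (0.03 log units; within the scatter) was within the scatter, no shift beyond the scatter is expected in this assay, in either direction. Compound 4 is therefore estimated at 70000 nM, with a range from 30000 nM to 160000 nM. The expected step is a 1.1-fold higher number from compound 1 to compound 4 (0.05 log units; within the scatter), a change no larger than the usual scatter.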

Compound 4, half-maximal inhibitory concentration: 19000 nM
For compound 4 the middle estimate is 3.7-fold (0.57 log units) above the measured one, outside the stated range (below it).
By their numbers in this assay, from the lowest: compound 4; then compounds 1, 2 and 3 (each within the scatter of the next).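

In this assay the change from ethoxy to 2,2,2-trifluoroethoxy gives a 3.3-fold lower number from compound 1 to compound 4 (0.52 log units; beyond the scatter) and is the only step shown so far to lie beyond the scatter, so this place on the saturated chain carbon bound to the aromatic oxygen can affect the read-out, though only modestly. The earlier exchange involving fluorine on the aromatic oxygen, a 1.1-fold higher number from compound 2 to compound 3 (0.03 log units; within the scatter), stayed within the scatter, but it swapped different groups and sits on a different remainder of the molecule, so compound 4 and compound 3 together show that adding fluorine on this side of the molecule does not give one uniform result. Nothing measured here explains the gain seen with compound 4.

From the compounds shown here alone, it remains open whether a longer chain, such as propoxy or 3,3,3-trifluoropropoxy, would lower the number further, and whether an amine or a carboxylic acid at this place would keep or lose the gain. Going by these compounds, it is also open whether 2,2,2-trifluoroethoxy would give a similar step on the core of compound 3, and whether the step would hold in other cell lines.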